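The source may hold more compounds than are shown below. What is called first, only, known or untested is meant among the compounds shown, and "the series" means these compounds.

Measured so far:
compound 1 `COc1ncc(-c2ccc3ncnc(Nc4ccc(OCCO)cc4)c3c2)cc1NS(=O)(=O)c1ccc(F)cc1F`: 2690 nM
compound 2 `COc1ncc(-c2ccc3ncnc(Nc4ccc(OCCCO)nc4)c3c2)cc1NS(=O)(=O)c1ccc(F)cc1F`: 9360 nM

In a functional assay on A549 cells (Homo sapiens) for antiproliferative activity, read by sulforhodamine B assay, with a stated time of 72 h (a lower number here means a stronger inhibitor, a higher number a weaker inhibitor), compound 1 gives 2690 nM, the lower of the two numbers, while compound 2 gives 9360 nM. For the measured compounds named here, the single measured step, a 3.5-fold higher number from compound 1 to compound 2 (0.54 log units; beyond the scatter), replaces the whole aryl group on the nitrogen, so it does not speak to the change now in view. Compound 3 `COc1cc(Nc2ncnc3ccc(-c4cnc(OC)c(NS(=O)(=O)c5ccc(F)cc5F)c4)cc23)ccc1OCCO` differs from compound 1 by methoxy in place of hydrogen on an aromatic carbon. Going by the values given here, with no comparable step measured, the expectation is a change within the scatter, a 1.0-fold higher number from compound 1 to compound 3 (0.00 log units; within the scatter). Compound 3 is therefore estimated at 2700 nM, with a range from 1000 nM to 7500 nM.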

Compound 3, half-maximal inhibitory concentration: 3760 nM
Compound 3: middle estimate off by 1.4-fold (0.14 log units), on the low side; measured number inside the range.
By their numbers in this assay, from the lowest: compounds 1 and 3 (each within the scatter of the next); then compound 2.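

In this assay, methoxy in place of hydrogen on the aromatic carbon ortho to the 2-hydroxyethoxy group gives a 1.4-fold higher number from compound 1 to compound 3 (0.15 log units; within the scatter), so this position accepts the added group with no change beyond the scatter. The larger swap of the whole aryl group gives a 2.5-fold lower number from compound 2 to compound 3 (0.40 log units; beyond the scatter), which places compound 3 with compound 1, clear of compound 2. Nothing available explains either step. From the compounds shown here alone, whether fluorine, ethoxy or a dimethylamino group at this position would behave like methoxy remains open. So does whether methoxy would be accepted elsewhere on this ring.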